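Enlarging the sulfonyl group of compound 3: an expectation

The compounds below may be only part of what the source reports. "The series", "measured", "known", "first", "only" and "open" are said of these compounds alone.

Compound 3 `CN(C)c1ccc(C2CC(c3ccc(-n4cncn4)cc3)=NN2S(C)(=O)=O)cc1`: 10.8%
Compound 1 `CN(C)c1ccc(C2CC(c3ccc(-n4cncn4)cc3)=NN2C(=O)CCCl)cc1`: -3.4%
Compound 2 `COC(=O)CC(=O)N1N=C(c2ccc(-n3cncn3)cc2)CC1c1ccc(N(C)C)cc1`: -7.8%

In a functional assay on HCC1806 cells (Homo sapiens) for inhibition, read by sulforhodamine B assay, tested at 10 uM (on this read-out lower numbers stand for less inhibition and higher numbers for more inhibition at the one concentration tested (going by the name of the read-out)), compound 3 stands highest of the three numbers, as the steps of a number 14.2 percentage points higher from compound 1 to compound 3 (beyond the scatter) and a number 18.6 percentage points higher from compound 2 to compound 3 (beyond the scatter) show; by contrast a number 4.4 percentage points lower from compound 1 to compound 2 (within the scatter) lies within the scatter. Both steps beyond the scatter concern the group on the ring nitrogen, where methylsulfonyl replaced an acyl group. Compound 4 `Cc1ccc(S(=O)(=O)N2N=C(c3ccc(-n4cncn4)cc3)CC2c2ccc(N(C)C)cc2)cc1` keeps that sulfonyl and differs from compound 3 only by 4-methylphenyl in place of methyl on a sulfonyl sulfur. Within the data shown here, no measured step alters the substituent on the sulfonyl sulfur, so the earlier steps bear on it only by showing that the sulfonyl itself is kept. A step of a number 3.2 percentage points higher from compound 3 to compound 4 (within the scatter) is therefore expected, within the scatter, and compound 4 is estimated at 14%, between 0% and 30%.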

Compound 4, a percentage reported as inhibition, at one concentration (the size of the read-out at that concentration, not a potency): 27.7%
Estimate against measurement, compound 4: 13.7 percentage points below; low and high end bracket the measured number.
By their numbers in this assay, from the lowest: compounds 2 and 1 (each within the scatter of the next); then compound 3; then compound 4.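

In this assay the substituent on the sulfonyl sulfur proves not to be neutral: 4-methylphenyl in place of methyl gives a number 16.9 percentage points higher from compound 3 to compound 4 (beyond the scatter) and so the sulfonyl alone does not set the number. Against the acyl groups, (4-methylphenyl)sulfonyl gives a number 35.5 percentage points higher from compound 2 to compound 4 (beyond the scatter) and a number 31.1 percentage points higher from compound 1 to compound 4 (beyond the scatter) and both steps are large. Nothing measured here accounts for this rise.

From the compounds shown here alone, whether the rise needs the aromatic ring or would also come with a longer chain such as butyl stays open. So does what a phenyl, a 4-chlorophenyl or a 4-methoxyphenyl on the sulfonyl sulfur would give.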